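A few compounds are considered here, and "the series" means these few. Any claim that something is new, unique, unknown or untested is made for them only; others in the source may bear on it.

Compound 1, with the structure `CC(=O)N(C)C(C)C#CCn1ccnc1`, is the only one of the three measured compounds that gives a number rather than a limit. In a functional assay on the whole organism for agonist activity, with Mus musculus as the target (a higher number here means that more compound is needed for the effect, a lower number that less compound is needed), compound 1 gives 3 mg/kg. Compound 2, with the structure `CC(=O)N(C)C(C)C#CCn1cncc1C`, differs from it by a single change: methyl in place of hydrogen on an aromatic carbon. For compound 2 this assay gives only a limit, > 100 mg/kg. That change therefore costs a great deal, an at least 33-fold higher number from compound 1 to compound 2 (1.52 log units; beyond the scatter), and both compound 2 and compound 3 sit at the same point, (the limit of > 100 mg/kg in this assay, at which 2 of the 3 values shown sit).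

Compound 3, with the structure `CCOC(=O)N(C)CC#CCn1ccnc1`, has a different core from compound 1; the difference between the two cores is not broken down here. For compound 3 this assay likewise gives only a limit, > 100 mg/kg.

Compound 4, with the structure `CCOC(=O)N(C)CC#CCn1cncc1C`, stands to compound 3 as compound 2 stands to compound 1: methyl in place of hydrogen on an aromatic carbon. The change is the same, on the same place of the ring, so the expectation for compound 4 rests on what it did between compound 1 and compound 2. Because an at least 33-fold higher number from compound 1 to compound 2 (1.52 log units; beyond the scatter) was large, and because compound 3 already sits at > 100 mg/kg, compound 4 is expected to stay at or beyond that limit, with an expected step that the limit leaves unreadable from compound 3 to compound 4. The estimate for compound 4 in this assay is 300 mg/kg, between 100 mg/kg and 3000 mg/kg.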

Compound 4, dose for half-maximal effect: > 100 mg/kg
Compound 4: only a limit was reported; the forecaster's own chance of this, stated with the estimate: 85%; the middle value lies beyond the limit too.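

In this assay compound 4 gives > 100 mg/kg as a limit, not a number. Within the data shown here, compound 3 also gives only a limit, so no step between compound 3 and compound 4 can be read, and the two share one point: the limit of > 100 mg/kg in this assay, at which 3 of the 4 values shown sit. From the compounds shown here alone, what stays open is whether methyl in place of hydrogen on the aromatic carbon changes anything on the core of compound 3.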